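Working notes: one more group on the shared core

The source may hold more compounds than are shown below. What is called first, only, known or untested is meant among the compounds shown, and "the series" means these compounds.

Measured in a functional assay on HCT-116 cells (Homo sapiens) for cytotoxicity, read by MTT assay, with a stated time of 72 h; on this read-out lower numbers stand for stronger inhibition and higher numbers for weaker inhibition:
- compound 1 `Nc1ccccc1NC(=O)c1ccc(CNc2nccc(-c3cnc4ccccn34)n2)cc1`: 82 nM
- compound 2 `Nc1ccccc1NC(=O)c1ccc(CNc2nccc(-c3cnc4cnccn34)n2)cc1`: 214 nM

For the measured compounds named here, of these two numbers, compound 2 has the higher, at 214 nM, and compound 1 is its only neighbour. Compound 3 `Cc1nc2ccccn2c1-c1ccnc(NCc2ccc(C(=O)Nc3ccccc3N)cc2)n1` has not yet been measured. Its difference from compound 2 is a group of 10 heavy atoms (8 carbon, 2 nitrogen; one five-membered aromatic ring with 2 hetero atoms, one six-membered aromatic ring with 1 hetero atom) in place of a group of 9 heavy atoms (6 carbon, 3 nitrogen; one five-membered aromatic ring with 2 hetero atoms, one six-membered aromatic ring with 2 hetero atoms), on an aromatic carbon. The exchange sits on an aromatic carbon of a six-membered aromatic ring with 2 nitrogen.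

Going by the values given here, only one measured step bears on this: a 2.6-fold higher number from compound 1 to compound 2 (0.42 log units; beyond the scatter). There, a group with a six-membered aromatic ring with 1 hetero atom gave way to one with a six-membered aromatic ring with 2 hetero atoms, and the number rose modestly. Among the compounds with values here, compound 3 again carries a six-membered aromatic ring with 1 hetero atom, but its group is larger than that of compound 1, and no measured step isolates that difference. A modest move towards a lower number is therefore expected, similar in size to the measured step but uncertain. The expected change is a 2.1-fold lower number from compound 2 to compound 3 (0.33 log units; beyond the scatter). For compound 3 the estimate is 100 nM, with an expected range of 40 nM to 250 nM.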

Compound 3, half-maximal inhibitory concentration: 203 nM
The estimate for compound 3 lay 2.0-fold (0.31 log units) below the measured number; the range from low to high includes it.
By their numbers in this assay, from the lowest: compound 1; then compounds 3 and 2 (each within the scatter of the next).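

In this assay, methyl in place of hydrogen on an aromatic carbon of the group gives a 2.5-fold higher number from compound 1 to compound 3 (0.39 log units; beyond the scatter) and so, among the three compounds, a second change to this group moves the number the same way as the extra ring nitrogen, which gave a 2.6-fold higher number from compound 1 to compound 2 (0.42 log units; beyond the scatter) in the earlier pair. The two groups on the aromatic carbon of the six-membered aromatic ring with 2 nitrogen cannot be told apart here, as the comparison gives a 1.1-fold lower number from compound 2 to compound 3 (0.02 log units; within the scatter) and lies within the scatter, although they differ in heavy atoms and hydrogen-bond acceptors. Nothing available accounts for either step.

Compound 1 alone stands apart from the other two, and three compounds do not show whether any substituent on that aromatic carbon of the group would raise the number or whether this holds for methyl only. An ethyl, a methoxy or an amine at the same carbon would separate the effect of size from that of the group's identity, and a methyl on the group of compound 2 would show whether the two changes add up.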